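Branching the Butyl Chain on a Cyanoguanidine Core

The compounds below may be only part of what the source reports. "The series", "measured", "known", "first", "only" and "open" are said of these compounds alone.

Measured compounds:
- compound 1, `CCCC/N=C(\NC#N)Nc1cccnc1`: 20 mg/kg
- compound 2, `CCCCC(CC)C/N=C(\NC#N)Nc1cccnc1`: > 50 mg/kg

For the measured compounds named here, in a functional assay on the whole organism (blood, strain Wistar-Okamoto) with Rattus norvegicus as the target, with a stated time of 5 days (on this read-out higher numbers stand for an effect only at larger amounts of compound and lower numbers for an effect already at smaller amounts), compound 1 gives 20 mg/kg, the only plain number among the measured values. Compound 2 is recorded in this assay only as a limit, > 50 mg/kg, not as a number. Going by the values given here, the step of an at least 2.5-fold higher number from compound 1 to compound 2 (0.39 log units; beyond the scatter) is the one measured change, and it sits at the limit of > 50 mg/kg in this assay, at which 1 of the 2 values shown sits, so its size is known only as a lower bound.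

Compound 3, `CCC(C)/N=C(\NC#N)Nc1cccnc1`, has not yet been measured. It differs from compound 1 by sec-butyl in place of butyl on a double-bonded nitrogen; the two have the same atoms, joined differently. Among the compounds with values here, the one measured step adds butyl on the chain, which is a larger change than this rearrangement, so it speaks only loosely to compound 3. Since that step went to a higher number and the branching here is the smaller change, a modest shift toward a higher number, or none beyond the scatter, is expected: a 1.5-fold higher number from compound 1 to compound 3 (0.18 log units; within the scatter). Compound 3 is therefore estimated at 30 mg/kg, with a range from 10 mg/kg to 100 mg/kg.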

Compound 3, minimum effective dose: 20 mg/kg
For compound 3 the middle estimate is 1.5-fold (0.18 log units) above the measured one; measured number inside the range.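

Moving the attachment point within the same four carbons, so that sec-butyl stands in place of butyl on the double-bonded nitrogen, leaves the read-out in this assay unmoved: there is no change at the digits printed from compound 1 to compound 3 (within the scatter). Unlike the earlier step, this comparison rests on two plain numbers, so its size can be read directly rather than as a lower bound, and it shows that a branched chain of this size at this position is compatible with the value of the straight butyl chain. Compound 2, which carries a larger branched chain, is recorded only as a limit, so the upper end of its step stays unknown: the limit of > 50 mg/kg in this assay, at which 1 of the 3 values shown sits.

On these data alone, whether a tert-butyl group, a cyclopentyl ring or a shorter chain such as ethyl at this nitrogen would keep the number where it stands remains open. Also open, as far as these compounds go, is how a chain ending in an amine or a carboxylic acid would behave in this assay, and the equal numbers of these two compounds alone cannot say what lies behind them.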